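Drawing the stereocentre of the ethoxy compound

A few compounds are considered here, and "the series" means these few. Any claim that something is new, unique, unknown or untested is made for them only; others in the source may bear on it.

In a functional assay (mast cells) for inhibition, with Rattus norvegicus as the target (on this read-out higher numbers stand for an effect only at larger amounts of compound and lower numbers for an effect already at smaller amounts), compound 1 `CC1CC/C(=N\Nc2ccc(Br)cc2)c2ncc(C(=O)O)c(=O)n21` gives 2000 nM, compound 2 `C[C@@H]1CC/C(=N\Nc2ccc(O)cc2)c2ncc(C(=O)O)c(=O)n21` gives 15600 nM and compound 3 `CCOc1ccc(N/N=C2\CCC(C)n3c2ncc(C(=O)O)c3=O)cc1` gives 17600 nM. Compound 3 lies within the scatter of compound 2. Within the data shown here, the one measured step, an 8.8-fold higher number from compound 1 to compound 3 (0.94 log units; beyond the scatter), puts ethoxy in place of bromo on an aromatic carbon. Compound 4 `CCOc1ccc(N/N=C2\CC[C@@H](C)n3c2ncc(C(=O)O)c3=O)cc1` has the same atoms and bonds as compound 3, with the two compounds have the same atoms and bonds; at least one stereo element is drawn with a configuration in one of them and without one in the other: 1 of 2 stereo elements differ; a stereocentre at a saturated ring carbon is drawn without a configuration in compound 3 and R in compound 4: a stereocentre at a saturated ring carbon is drawn without a configuration in compound 3 and R in compound 4. Among the measured compounds shown here, the measured step does not touch that stereocentre, so no step bears on this change directly, and none beyond the scatter is expected in this assay. The estimated step is a 1.2-fold lower number from compound 3 to compound 4 (0.07 log units; within the scatter). Compound 4 is expected at 15000 nM, within a range of 7000 nM to 30000 nM.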

Compound 4, half-maximal effective concentration: 1000 nM
Compound 4: middle estimate off by 15-fold (1.18 log units), on the high side, outside the stated range (below it).
By their numbers in this assay, from the lowest: compounds 4 and 1 (each within the scatter of the next); then compounds 2 and 3 (each within the scatter of the next).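

In this assay, among these compounds, the stereocentre at the saturated ring carbon proves to matter, with an 18-fold lower number from compound 3 to compound 4 (1.25 log units; beyond the scatter) as the drawing of R is the only change. The ethoxy group is also no longer level with the hydroxy group: with the centre drawn alike, ethyl in place of hydrogen on the oxygen gives a 16-fold lower number from compound 2 to compound 4 (1.19 log units; beyond the scatter) on this read-out. The stereo step must be read with one limit in mind: the fact that one of compounds 3 and 4 is drawn with a defined configuration and the other without, at the place where they differ.

The compounds shown leave open how the S configuration at this carbon reads and what compound 3 actually contains there. They also leave open what an amine or a longer alkoxy chain would give on the aromatic carbon.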